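Weighing a Nitrophenyl Swap on Compound 2

The source may hold more compounds than are shown below. What is called first, only, known or untested is meant among the compounds shown, and "the series" means these compounds.

Measured so far in a functional assay on A549 cells (Homo sapiens) for cytotoxicity, read by MTT assay, with stated times of 48 h and 4 h; on this read-out higher numbers stand for weaker inhibition and lower numbers for stronger inhibition
- compound 1 `COc1ccc(/C=C/c2nc(NCCN(C(C)C)C(C)C)c3ccccc3n2)cc1OC` gives 38800 nM
- compound 2 `COc1ccc(/C=C/c2nc(NCCN3CCCCC3)c3ccccc3n2)cc1OC` gives 82700 nM
- compound 3 `COc1ccc(/C=C/c2nc(NCCN3CCCCC3)c3cc(Cl)ccc3n2)cc1OC` gives > 100000 nM, a limit

Compound 2 has the higher of the two actual numbers, with compound 1 the nearest below it. Compound 3 reports only a limit of the assay, > 100000 nM.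

Compound 4 `O=[N+]([O-])c1ccc(/C=C/c2nc(NCCN3CCCCC3)c3ccccc3n2)cc1` is unmeasured and differs from compound 2 as follows: 4-nitrophenyl in place of 3,4-dimethoxyphenyl on a double-bonded chain carbon bound to a double-bonded chain carbon. The measured steps are a 2.1-fold higher number from compound 1 to compound 2 (0.33 log units; beyond the scatter) and an at least 1.2-fold higher number from compound 2 to compound 3 (0.08 log units; that floor lies within the scatter). Both are small, and neither changes the group exchanged here, so they suggest no direction. The expected change is a 1.4-fold lower number from compound 2 to compound 4 (0.14 log units; within the scatter), which is no step beyond the scatter. For compound 4 the estimated value in this assay is 60000 nM, with an expected range from 15000 nM to 100000 nM.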

Compound 4, half-maximal inhibitory concentration: 28200 nM
Compound 4: the middle estimate sits 2.1-fold (0.33 log units) above what was measured, within the range that was stated.
By their numbers in this assay, from the lowest: compounds 4 and 1 (each within the scatter of the next); then compound 2. At a limit, above all of these: compound 3.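

The earlier steps shown here changed only the amine and the chloro, leaving the aryl group on the double-bonded chain carbon untested. In this assay, 4-nitrophenyl in place of 3,4-dimethoxyphenyl gives a 2.9-fold lower number from compound 2 to compound 4 (0.47 log units; beyond the scatter), so the 3,4-dimethoxyphenyl group is not required for this level of cytotoxicity, and a change at this place can move the number beyond the scatter.

From the compounds shown here alone, whether the lower number follows from the added nitro group or the lost methoxy groups stays open, as does how a nitrile or an amino group would behave there. Nothing given here supplies a reason for this step.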